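This account rests on a few compounds, and the source may have more. Where it says the series, first, only, none or still open, it means among the compounds named here.

Of the compounds shown here, three share one core and have been tested in a functional assay on J774 cells (Mus musculus) for cytotoxicity, read by resazurin assay, with a stated time of 72 h; a lower number here means a stronger inhibitor, a higher number a weaker inhibitor. Compound 1 `O=S(=O)(Nc1cccc(CO)c1)c1ccc(-c2ccccc2)cc1` gives 2200 nM. Compound 2 `O=S(=O)(Nc1cccc(CO)c1)c1ccc(-c2ccc(Br)cc2)cc1` gives 2500 nM, and compound 3 `O=S(=O)(Nc1cccc(CO)c1)c1ccc(-c2ccc(Cl)cc2)cc1` gives 2500 nM. The step of a 1.1-fold higher number from compound 1 to compound 2 (0.06 log units; within the scatter) and the step of a 1.1-fold higher number from compound 1 to compound 3 (0.06 log units; within the scatter) both stay inside the usual scatter, as does no change at the digits printed from compound 2 to compound 3 (within the scatter), so these three numbers cannot be told apart.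

Compound 4 `O=S(=O)(Nc1ccc(Cl)c(CO)c1)c1ccc(-c2ccc(Br)cc2)cc1` has not yet been tested. It differs from compound 2 by chloro in place of hydrogen on an aromatic carbon. The same kind of change, chloro in place of hydrogen on an aromatic carbon, is already on record from compound 1 to compound 3, where the difference is chloro in place of hydrogen on an aromatic carbon and the step was a 1.1-fold higher number from compound 1 to compound 3 (0.06 log units; within the scatter). The two changes are not the same, however: in compound 3 the chloro sits para to a large group, whereas in compound 4 it sits ortho to a hydroxymethyl group (2 heavy atoms) and para to a large group. The cores of compound 2 and compound 1 differ by bromo in place of hydrogen on an aromatic carbon.

Because the earlier step of a 1.1-fold higher number from compound 1 to compound 3 (0.06 log units; within the scatter) lay within the scatter, the step from compound 2 to compound 4 is expected to be small as well, estimated at no change at the digits printed from compound 2 to compound 4 (within the scatter). For compound 4 the estimated value in this assay is 2500 nM, with a range from 1200 nM to 5500 nM.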

Compound 4, half-maximal inhibitory concentration: > 5000 nM
Compound 4 was reported as a limit; the forecaster's own chance of this, stated with the estimate: 5%; middle value at least 2.0-fold (0.30 log units) from the limit.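

In this assay compound 4 reads > 5000 nM, which is a limit of the assay and not a number. Putting chloro in place of hydrogen therefore gives an at least 2.0-fold higher number from compound 2 to compound 4 (0.30 log units; that floor lies within the scatter), a step known only by its floor, with no upper end, and here the chloro sits ortho to a hydroxymethyl group and para to a large group. Set beside the earlier case, the result neither shows that this change carries over unchanged from one core to another nor shows that it behaves differently, and the comparison can be taken only this far: the same change on two cores in this assay, a 1.1-fold higher number (0.06 log units; within the scatter) from compound 1 to compound 3 and an at least 2.0-fold higher number (0.30 log units; that floor lies within the scatter) from compound 2 to compound 4; the limit leaves it open whether they differ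

The compounds shown leave open where the true number for compound 4 lies, and so how large its step really is, as well as whether the same chloro placed on the core of compound 1, without the bromo, would give a similar reading. They also leave open how a different group at that same place, such as a methoxy group, an amine or a carboxylic acid, would read in this assay.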